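The source may hold more compounds than are shown below. What is called first, only, known or untested is meant among the compounds shown, and "the series" means these compounds.

Measured so far:
In a functional assay on MGC-803 cells (Homo sapiens) for cytotoxicity, read by MTT assay, with a stated time of 72 h (on this read-out higher numbers stand for weaker inhibition and lower numbers for stronger inhibition), compound 1 `NC(=O)N1CCN(C(=S)SCc2cn(Cc3ccccc3F)nn2)CC1` gives 11300 nM.
In this assay compound 2 `O=C(NCc1ccccc1)N1CCN(C(=S)SCc2cn(Cc3ccccc3F)nn2)CC1` gives 13300 nM.

Compound 1 stands at one end of the two numbers shown and compound 2 at the other, but the gap between them, a 1.2-fold higher number from compound 1 to compound 2 (0.07 log units; within the scatter), is within the scatter, so the two cannot be told apart on this read-out. That single step was made by placing benzyl in place of hydrogen on an amide-type nitrogen.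

Compound 3 `Cc1ccc(Cn2cc(CSC(=S)N3CCN(C(N)=O)CC3)nn2)cc1` has not yet been measured. It differs from compound 1 by 4-methylphenyl in place of 2-fluorophenyl on a saturated chain carbon bound to an aromatic nitrogen. Within the data shown here, no measured step touches this place: the only step available concerns a different site of the shared core, and its size within the scatter gives no hint about an exchange at the saturated chain carbon bound to an aromatic nitrogen. The two measured values also lie close together. Given this, no movement beyond the scatter is expected in this assay in either direction. Compound 3 is therefore estimated at 11000 nM, with a range from 4500 nM to 28000 nM. The step this estimate implies, a 1.0-fold lower number from compound 1 to compound 3 (0.01 log units; within the scatter), is expected to stay within the scatter.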

Compound 3, half-maximal inhibitory concentration: 29900 nM
The estimate for compound 3 lay 2.7-fold (0.43 log units) below the measured number, outside the stated range (above it).
By their numbers in this assay, from the lowest: compounds 1 and 2 (each within the scatter of the next); then compound 3.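

In this assay, replacing 2-fluorophenyl with 4-methylphenyl on a saturated chain carbon bound to an aromatic nitrogen gives a 2.6-fold higher number from compound 1 to compound 3 (0.42 log units; beyond the scatter), a modest step but one beyond the scatter, and the direction is toward weaker inhibition. Among these compounds, the only earlier step, a 1.2-fold higher number from compound 1 to compound 2 (0.07 log units; within the scatter), stayed within the scatter, so this is the first place where a single exchange moves the read-out measurably, even though the two groups are counted alike in heavy atoms and each holds one six-membered aromatic ring of carbon only. No measurement at hand offers an explanation for this step.

The compounds shown leave open whether the step goes with the fluorine leaving, the methyl entering, or both, and an unsubstituted phenyl at this place would bear directly on that question. As far as these compounds go, it also remains open whether the same exchange would have a similar effect on compound 2, and whether a group such as an amine or a carboxylic acid on this aromatic ring would move the number in either direction.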